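The compounds below may be only part of what the source reports. "The series", "measured", "known", "first", "only" and "open" are said of these compounds alone.

Working notes on the series built on the shared core of compound 1 (`O=C(NNc1ccnc2cc(Cl)ccc12)c1ccccc1/N=C/c1ccccc1Cl`), followed in a physicochemical assay for lipophilicity, measured as octanol-water partition; a higher number here means a more lipophilic compound, a lower number a more polar compound. Compound 1 gives 5.5, and compound 2 (`O=C(NNc1ccnc2cc(Cl)ccc12)c1ccccc1/N=C/c1ccc(Cl)cc1`) gives 5.62. These two are not separated, with a number 0.12 log units higher from compound 1 to compound 2 (within the scatter). Compound 3 (`COc1ccc(/C=N/c2ccccc2C(=O)NNc2ccnc3cc(Cl)ccc23)cc1`), the 4-methoxyphenyl member, gives 5, the lowest of the three numbers, and both others stand beyond the scatter from it.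

Next in line is compound 4 (`O=C(NNc1ccnc2cc(Cl)ccc12)c1ccccc1/N=C/c1ccc(O)cc1`), the 4-hydroxyphenyl member. The change is hydrogen in place of methyl on an oxygen on an aromatic ring, or methoxy to hydroxy.

Among the compounds with values here, two measured steps bear on this, since both end at the methoxy group of compound 3: a number 0.50 log units lower from compound 1 to compound 3 (beyond the scatter), and a number 0.62 log units lower from compound 2 to compound 3 (beyond the scatter). Both are modest. Within the data shown here, neither involves a hydroxy group, so they offer a scale for the size of a step and no direct precedent.

The number is expected to fall further, by an amount similar to those two steps. The expected step is a number 0.50 log units lower from compound 3 to compound 4 (beyond the scatter). For compound 4 the estimated value is 4.5, with an expected range of 4.1 to 4.9.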

Compound 4, partition coefficient: 4.65
Beside the measured number, compound 4's estimate is 0.15 log units below it; measured number inside the range.
By their numbers in this assay, from the lowest: compound 4; then compound 3; then compounds 1 and 2 (each within the scatter of the next).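

Within the data shown here, the step on the oxygen on an aromatic ring, a number 0.35 log units lower from compound 3 to compound 4 (beyond the scatter), is the first reading of a hydroxy group in this assay, and it shows that hydrogen in place of methyl there moves the number beyond the scatter, in the same direction as the earlier steps to the methoxy member. Set against the chlorinated members, hydroxy in place of chloro gives a number 0.97 log units lower from compound 2 to compound 4 (beyond the scatter), and 4-hydroxyphenyl in place of 2-chlorophenyl gives a number 0.85 log units lower from compound 1 to compound 4 (beyond the scatter), so compound 4 now holds the lowest number of the four, beyond the scatter from each of the others. No measurement at hand accounts for the size of these steps.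

The compounds shown leave open how an amine or a carboxylic acid in place of the hydroxy group would read, and whether a longer chain on the same oxygen, such as ethyl in place of methyl, would stand apart from compound 3. They also leave open whether 2-hydroxyphenyl would stay within the scatter of 4-hydroxyphenyl, as the two chlorophenyl members do of each other.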